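The compounds below may be only part of what the source reports. "The series", "measured", "known", "first", "only" and "open" are said of these compounds alone.

Measured so far:
Compound 1 `C[C@H](Nc1nc(N)nc(N)c1C#N)c1cc2ccc(F)cn2c(=O)c1-c1ccccc1` — 88%
Compound 2 `Cc1cccc(-c2c([C@H](C)Nc3nc(N)nc(N)c3C#N)cc3ccc(F)cn3c2=O)c1` — 77%
Compound 3 `C[C@H](Nc1nc(N)nc(N)c1C#N)c1cc2ccc(F)cn2c(=O)c1-c1ccc(F)cc1` — 87%

In an ADME assay on microsomes from liver (Rattus norvegicus), read by LC-MS, using NADPH, with a stated time of 30 min, tested at 1 uM (on this read-out lower numbers stand for a less stable compound and higher numbers for a more stable compound), compound 3 sits between the other two, with both gaps inside the scatter: a number 10 percentage points higher from compound 2 to compound 3 (within the scatter) and a number 1 percentage points lower from compound 1 to compound 3 (within the scatter). Compound 4 `Cc1cc(F)cc(-c2c([C@H](C)Nc3nc(N)nc(N)c3C#N)cc3ccc(F)cn3c2=O)c1` carries the change (3-fluoro-5-methylphenyl in place of 4-fluorophenyl on an aromatic carbon). Among the measured compounds shown here, two steps bear on it. Placing a methyl on the aryl ring gave a number 11 percentage points lower from compound 1 to compound 2 (beyond the scatter), a modest drop; placing a fluoro gave a number 1 percentage points lower from compound 1 to compound 3 (within the scatter), no real change. Compound 4 holds both a methyl and a fluoro on that ring, so a modest drop in this assay of about the size seen for the methyl is expected, rather than none. Compound 4 is therefore estimated at 76% (62% to 88%), an expected step of a number 11 percentage points lower from compound 3 to compound 4 (beyond the scatter).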

Compound 4, percent of the compound remaining: 60%
Beside the measured number, compound 4's estimate is 16 percentage points above it, and the stated range ends above it.
By their numbers in this assay, from the lowest: compound 4; then compounds 2, 3 and 1 (each within the scatter of the next, the first and the last beyond it).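

In this assay, among the compounds shown here, this aryl position proves less forgiving than the earlier compounds suggested: 3-fluoro-5-methylphenyl gives a number 27 percentage points lower from compound 3 to compound 4 (beyond the scatter) and, against phenyl, a number 28 percentage points lower from compound 1 to compound 4 (beyond the scatter) as well. A fluoro that did nothing on phenyl counts once a methyl is on the ring, with a number 17 percentage points lower from compound 2 to compound 4 (beyond the scatter) as the step. The effect of fluoro therefore depends on the ring that receives it: the same change on two cores in this assay, a number 1 percentage points lower (within the scatter) from compound 1 to compound 3 and a number 17 percentage points lower (beyond the scatter) from compound 2 to compound 4, 16 percentage points apart, beyond the scatter of two such steps.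

From the compounds shown here alone, whether the loss follows the methyl or the different place of the fluoro stays open, since 4-fluorophenyl and 3-fluoro-5-methylphenyl differ in both. Going by these compounds, how a methoxy or an amine on this ring would read also remains open.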